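Urea series, amide-nitrogen swap from cyclohexyl to benzyl

A few compounds are considered here, and "the series" means these few. Any claim that something is new, unique, unknown or untested is made for them only; others in the source may bear on it.

Measured so far:
compound 1, `Cc1cc(Cl)c(NC(=O)N(Cc2ccc(Oc3ccc(F)cc3)cc2)C2CCCCCC2)c(Cl)n1`, 14 nM in an assay for inhibition of acyl-CoA:cholesterol acyltransferase (Oryctolagus cuniculus), using microsomes; a lower number here means a stronger inhibitor, a higher number a weaker inhibitor
compound 2, `CSc1cc(C)nc(SC)c1NC(=O)N(Cc1ccc(Oc2ccc(F)cc2)cc1)C1CCCCC1`, 23 nM in this assay

Compound 2 has the higher of the two numbers, yet its value and that of compound 1 lie within the usual scatter of one another, so no order between them can be read. Compound 3, `CSc1cc(C)nc(SC)c1NC(=O)N(Cc1ccccc1)Cc1ccc(Oc2ccc(F)cc2)cc1`, differs from compound 2 in one place: benzyl in place of cyclohexyl on an amide-type nitrogen. Within the data shown here, no step between measured compounds bears on this swap, so the expectation rests on the change alone. A moderate weakening is expected, a step of a 3.5-fold higher number from compound 2 to compound 3 (0.54 log units; beyond the scatter) from compound 2 to compound 3. For compound 3 the estimate is 80 nM, with a range of 20 nM to 350 nM.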

Compound 3, half-maximal inhibitory concentration: 9.1 nM
Estimate against measurement, compound 3: 8.8-fold (0.94 log units) above; the measured number lies below the stated range.
By their numbers in this assay, from the lowest: compounds 3, 1 and 2 (each within the scatter of the next, the first and the last beyond it).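

In this assay, benzyl in place of cyclohexyl on an amide-type nitrogen gives a 2.5-fold lower number from compound 2 to compound 3 (0.40 log units; beyond the scatter), so this position accepts an aromatic ring as well as a non-aromatic ring of carbon, at least on the core of compound 2. No available evidence accounts for this step.

Going by these compounds, the swap rests on this single pair, so whether it carries over to the core of compound 1 remains open. Also open, on these data alone, is how a phenethyl chain or a pyridylmethyl group would behave on this nitrogen.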